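This account rests on a few compounds, and the source may have more. Where it says the series, first, only, none or still open, it means among the compounds named here.

Measured compounds:
- compound 1, `CC(C)(C)c1ccc(NC(=O)CCCl)cc1`: 49000 nM
- compound 2, `CC(C)(C)c1ccc(NC(=O)CCCCl)cc1`: a limit, > 100000 nM
- compound 3, `C=CC(=O)Nc1ccc(I)cc1`: 17000 nM

In a functional assay on MCF7 cells (Homo sapiens) for antiproliferative activity, with a stated time of 48 h (a higher number here means a weaker inhibitor, a lower number a stronger inhibitor), compound 3 gives the lowest of the two numbers, and compound 1 is its nearest neighbour, with a higher number. For compound 2 this assay reports only a limit, > 100000 nM, not a number, so that value is one of the limits shown (the limit of > 100000 nM in this assay, at which 1 of the 3 values shown sits). Within the data shown here, the one step measured within this set, an at least 2.0-fold higher number from compound 1 to compound 2 (0.30 log units; that floor lies within the scatter), concerns the saturated chain on the carbonyl side of the amide and does not touch the aromatic ring.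

Compound 4, `C=CC(=O)Nc1ccc(C(C)(C)C)cc1`, is compound 3 with one change: tert-butyl in place of iodo on an aromatic carbon. Among the measured compounds shown here, no measured pair differs at that position alone; compound 1 and compound 3 carry the two groups in question but also differ in the chain on the carbonyl, so their values show only that both sit within a modest span of each other. For the measured compounds named here, there is therefore no measured step on which to build a firm direction, and the expectation is a step not clearly beyond the scatter.

Compound 4 is expected to give about 22000 nM in this assay, in a range from 7000 nM to 70000 nM, which corresponds to an expected step of a 1.3-fold higher number from compound 3 to compound 4 (0.11 log units; within the scatter).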

Compound 4, half-maximal inhibitory concentration: 29000 nM
Beside the measured number, compound 4's estimate is 1.3-fold (0.12 log units) below it, and the stated range covers the measured number.
By their numbers in this assay, from the lowest: compounds 3, 4 and 1 (each within the scatter of the next, the first and the last beyond it). At a limit, above all of these: compound 2.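

In this assay, among these compounds, the exchange of iodo for tert-butyl on an aromatic carbon gives the first measured step at this position, a 1.7-fold higher number from compound 3 to compound 4 (0.23 log units; within the scatter), so compound 3 and compound 4 cannot be told apart even though four carbon atoms replace one iodine atom. Among the compounds shown here, with tert-butyl held constant, compound 4 also allows the group on the carbonyl carbon to be compared on its own: vinyl in place of 2-chloroethyl gives a 1.7-fold lower number from compound 1 to compound 4 (0.23 log units; within the scatter), which again cannot be told apart, whereas vinyl in place of 3-chloropropyl gives an at least 3.4-fold lower number from compound 2 to compound 4 (0.53 log units; beyond the scatter), the only step here that clearly exceeds the scatter. That larger step has only a floor for its size, since the value of compound 2 is a limit and not a number: the limit of > 100000 nM in this assay, at which 1 of the 4 values shown sits.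

The compounds shown leave open whether an amine or a carboxylic acid on that aromatic carbon would give a number clearly different from those of iodo and tert-butyl. They also leave open how a longer chain without chlorine on the carbonyl carbon would compare with vinyl, 2-chloroethyl and 3-chloropropyl.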